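Swapping Methoxy for Methylsulfanyl on Compound 3

The compounds below may be only part of what the source reports. "The series", "measured", "known", "first", "only" and "open" are said of these compounds alone.

Of the compounds shown here, three built on one shared core have been tested in a functional assay on MKN-74 cells (Homo sapiens) for antiproliferative activity, with a stated time of 24 h; a higher number here means a weaker inhibitor, a lower number a stronger inhibitor. Compound 1 `NC(=O)c1c(NC(=O)c2ccccc2Cl)sc2c1CCN(Cc1ccc(Cl)cc1)C2` gives 18700 nM. Compound 2 `NC(=O)c1c(NC(=O)c2ccccc2Cl)sc2c1CCN(C(=S)Nc1cccc3ccccc13)C2` gives 20700 nM in this assay. Compound 3 `COc1ccccc1NC(=S)N1CCc2c(sc(NC(=O)c3ccccc3Cl)c2C(N)=O)C1` gives 35200 nM in this assay. The number for compound 3 is the largest of the three, yet the steps leading to it are small: a 1.9-fold higher number from compound 1 to compound 3 (0.27 log units; within the scatter) and a 1.7-fold higher number from compound 2 to compound 3 (0.23 log units; within the scatter), both inside the scatter of repeated measurements, so no real order among the three can be claimed.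

Compound 4 `CSc1ccccc1NC(=S)N1CCc2c(sc(NC(=O)c3ccccc3Cl)c2C(N)=O)C1` has not yet been measured. It differs from compound 3 in a single place: methylsulfanyl in place of methoxy on an aromatic carbon. For the measured compounds named here, no measured pair exchanges exactly these two groups, so there is no direct precedent. Going by the values given here, the only steps available, a 1.9-fold higher number from compound 1 to compound 3 (0.27 log units; within the scatter) and a 1.7-fold higher number from compound 2 to compound 3 (0.23 log units; within the scatter), involve larger exchanges and still stayed within the scatter, which gives no reason to expect that a small swap of methoxy for methylsulfanyl will move the number. The expected step is therefore a 1.2-fold lower number from compound 3 to compound 4 (0.07 log units; within the scatter), meaning no change beyond the scatter. Compound 4 is estimated at 30000 nM in this assay, with a range from 12000 nM to 80000 nM.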

Compound 4, half-maximal inhibitory concentration: 13800 nM
Estimate against measurement, compound 4: 2.2-fold (0.34 log units) above, and the stated range covers the measured number.
By their numbers in this assay, from the lowest: compounds 4, 1, 2 and 3 (each within the scatter of the next, the first and the last beyond it).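

In this assay, exchanging the oxygen of methoxy for the sulfur of methylsulfanyl gives a 2.6-fold lower number from compound 3 to compound 4 (0.41 log units; beyond the scatter). For the compounds shown here, this is the first step to rise beyond the scatter, although it is modest and the group that enters has the same count of heavy atoms and hydrogen-bond acceptors as the group that leaves, so at this place, ortho to a large group, a single-atom exchange can register in the assay where the larger exchanges behind compound 3 did not. The other two steps, a 1.5-fold lower number from compound 2 to compound 4 (0.18 log units; within the scatter) and a 1.4-fold lower number from compound 1 to compound 4 (0.13 log units; within the scatter), stay within the scatter, so compound 4 separates only from compound 3 and takes no rank of its own against compound 1 or compound 2, and nothing measured here accounts for the difference between the two groups.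

The compounds shown leave open how a longer sulfur chain such as ethylsulfanyl, or an amine or a chlorine at this same place, would read. They also leave open whether methylsulfanyl gives a similar step on a core carrying a different group in place of the 2-chlorobenzoyl amide.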